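The source may hold more compounds than are shown below. What is called first, only, known or untested is meant among the compounds shown, and "the series" means these compounds.

In a physicochemical assay for lipophilicity, measured as octanol-water partition (a higher number here means a more lipophilic compound, a lower number a more polar compound), compound 1 `O=C(NNc1ccnc2cc(Cl)ccc12)c1ccccc1/N=C/c1ccc(F)cc1` gives 5.18, compound 2 `O=C(NNc1ccnc2cc(Cl)ccc12)c1ccccc1/N=C/c1ccc(O)cc1` gives 4.65 and compound 3 `O=C(NNc1ccnc2cc(Cl)ccc12)c1ccccc1/N=C/C=C/c1ccccc1` gives 5.54. Compound 3 therefore stands highest of the three, as the two steps that reach it show: a number 0.36 log units higher from compound 1 to compound 3 (beyond the scatter) and a number 0.89 log units higher from compound 2 to compound 3 (beyond the scatter).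

Compound 4 `O=C(NNc1ccnc2cc(Cl)ccc12)c1ccccc1/N=C/c1cc2ccccc2nc1Cl` keeps the shared core and differs from compound 3 in one place: 2-chloroquinolin-3-yl in place of 2-phenylethenyl on a carbon with a double bond to nitrogen. In words, 2-chloroquinolin-3-yl sits in place of 2-phenylethenyl on a carbon with a double bond to nitrogen.

Going by the values given here, no measured step brings in this group, so the guidance is indirect. The steps at this same carbon are modest, and the one closest in kind is a number 0.36 log units higher from compound 1 to compound 3 (beyond the scatter). The largest drop seen, a number 0.53 log units lower from compound 1 to compound 2 (beyond the scatter), came with a hydroxy group, and the entering group has none, so a drop of that size is not expected here. The expected change is therefore none beyond the scatter, an estimated a number 0.11 log units higher from compound 3 to compound 4 (within the scatter). Compound 4 is expected at about 5.65, within a range from 5.2 to 6.1.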

Compound 4, partition coefficient: 6
Compound 4: middle estimate off by 0.35 log units, on the low side; the range from low to high includes it.
By their numbers in this assay, from the lowest: compound 2; then compound 1; then compound 3; then compound 4.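

In this assay, the carbon with a double bond to nitrogen can carry a group larger than 2-phenylethenyl, one holding a hydrogen-bond acceptor, and the number still climbs: 2-chloroquinolin-3-yl gives a number 0.46 log units higher from compound 3 to compound 4 (beyond the scatter), which puts compound 4 highest of the four. Going by these compounds alone, measured against the other two groups at this place, the change is a number 0.82 log units higher from compound 1 to compound 4 (beyond the scatter) and a number 1.35 log units higher from compound 2 to compound 4 (beyond the scatter), the latter being the only large step in this set. Nothing available shows which part of the entering group, whether its chlorine, its nitrogen or its second ring, accounts for this rise.

Still open, on these data alone, is how the number would move if 2-chloroquinolin-3-yl lost its chlorine. Also open, as far as these compounds go, is where a group bearing an amine or a carboxylic acid would fall at this carbon.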